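Swapping dimethylcarbamoyl for cyano on compound 2

This account rests on a few compounds, and the source may have more. Where it says the series, first, only, none or still open, it means among the compounds named here.

Measured so far in a physicochemical assay for lipophilicity, using the shake flask method, at pH 7.4; on this read-out higher numbers stand for higher lipophilicity and lower numbers for lower lipophilicity
compound 1 `CCCC(Oc1ccc(-n2cc3ccccc3n2)cc1)c1ccc(C(=O)NCCC(=O)O)cc1` gives 2.5
compound 2 `CCCC(Oc1ccc(-n2cc(C(=O)N(C)C)cn2)cc1)c1ccc(C(=O)NCCC(=O)O)cc1` gives 0.5

Within the data shown here, of these two compounds, compound 2 stands lowest, at 0.5 in this assay, and compound 1 is its only neighbour on the scale. The next structure is compound 3 `CCCC(Oc1ccc(-n2cc(C#N)cn2)cc1)c1ccc(C(=O)NCCC(=O)O)cc1`, which carries cyano in place of dimethylcarbamoyl on an aromatic carbon and otherwise matches compound 2.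

Among the measured compounds shown here, only one measured step bears on this change. That step is a number 2.00 log units lower from compound 1 to compound 2 (beyond the scatter), large and beyond the scatter, and it brought in 4-(dimethylcarbamoyl)-1H-pyrazol-1-yl in place of 2H-indazol-2-yl. For the measured compounds named here, no measured compound carries cyano, so this step gives a sense of scale and does not isolate the new group. Removing dimethylcarbamoyl while keeping the five-membered ring is expected to win back part of that distance, not all of it. The expected change is a number 0.80 log units higher from compound 2 to compound 3 (beyond the scatter), an upward step of moderate size. Compound 3 is estimated at 1.3 with an expected range of 0.9 to 1.8 on this scale.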

Compound 3, distribution coefficient: 1.2
The estimate for compound 3 lay 0.10 log units above the measured number, and the stated range covers the measured number.
By their numbers in this assay, from the lowest: compound 2; then compound 3; then compound 1.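

With the five-membered aromatic ring held constant, cyano in place of dimethylcarbamoyl gives a number 0.70 log units higher from compound 2 to compound 3 (beyond the scatter) in this assay, so the group on this aromatic carbon moves the number on its own. Ring and group changed together in the earlier pair, and that pair could not make this separation. The comparison with the original ring is also now sharper: 4-cyano-1H-pyrazol-1-yl in place of 2H-indazol-2-yl still gives a number 1.30 log units lower from compound 1 to compound 3 (beyond the scatter), so a change of ring that retains a small group at this position remains a large step. Nothing available here accounts for either step.

The compounds shown leave open where a carboxylic acid, a methyl group or a chlorine atom on this same aromatic carbon would fall on the scale, and two groups alone cannot show whether the number follows group size or some other feature. Going by these compounds, it also remains open whether cyano in place of dimethylcarbamoyl gives a step of similar size when the shared core carries a longer chain.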